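Dimethylamino for Methoxy on a Thiophene Nucleoside

A few compounds are considered here, and "the series" means these few. Any claim that something is new, unique, unknown or untested is made for them only; others in the source may bear on it.

In a functional assay on HCT-116 cells (Homo sapiens), read by MTT assay, with a stated time of 72 h (a higher number here means a weaker inhibitor, a lower number a stronger inhibitor), three compounds have been measured:
Compound 2 `COc1ncnc2c1c(-c1ccco1)cn2[C@@H]1O[C@H](CO)[C@@H](O)[C@H]1O` gives 40 nM.
Compound 3 `COc1ncnc2c1c(-c1ccsc1)cn2[C@@H]1O[C@H](CO)[C@@H](O)[C@H]1O` gives 120 nM.
Compound 1 `CN(C)c1ncnc2c1c(-c1cc3ccccc3o1)cn2[C@@H]1O[C@H](CO)[C@@H](O)[C@H]1O` gives only the assay limit, > 20000 nM.

Compound 3 stands highest of the two real numbers, separated from compound 2 by a 3.0-fold higher number from compound 2 to compound 3 (0.48 log units; beyond the scatter). Compound 4 `CN(C)c1ncnc2c1c(-c1ccsc1)cn2[C@@H]1O[C@H](CO)[C@@H](O)[C@H]1O` differs from compound 3 by dimethylamino in place of methoxy on an aromatic carbon. Going by the values given here, no measured step covers this change alone: the single measured step, a 3.0-fold higher number from compound 2 to compound 3 (0.48 log units; beyond the scatter), concerns a different position. Among the compounds with values here, compound 1 also carries dimethylamino and sits at the limit (the limit of > 20000 nM in this assay, at which 1 of the 3 values shown sits); it differs from compound 2 in two places, so that pair gives no clean step. Given the limit of compound 1 (the limit of > 20000 nM in this assay, at which 1 of the 3 values shown sits), a weakening step in this assay is expected, a 25-fold higher number from compound 3 to compound 4 (1.40 log units; beyond the scatter), with wide uncertainty. Compound 4 is estimated at 3000 nM, between 400 nM and 20000 nM.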

Compound 4, half-maximal inhibitory concentration: > 20000 nM
Compound 4: a limit, no number; the forecaster's own chance of this, stated with the estimate: 30%; middle value at least 6.6-fold (0.82 log units) from the limit.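

In this assay, putting dimethylamino in place of methoxy while keeping the thiophen-3-yl group gives an at least 160-fold higher number from compound 3 to compound 4 (2.22 log units; beyond the scatter), so this one change at this position is enough to lose nearly all the measurable activity. As far as these compounds go, compound 4 gives > 20000 nM, which is a limit and not a number, so the full size of the step stays unknown: the limit of > 20000 nM in this assay, at which 2 of the 4 values shown sit. The step between compound 1 and compound 4 cannot be read.

Still open, from the compounds shown here alone, is how a plain amino group or a methylamino group would behave at this position. Also open, going by these compounds, is whether dimethylamino has the same effect alongside the furan-2-yl group of compound 2.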